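A Branched Alkyl Chain Replaces the Ethoxyethyl Arm

This account rests on a few compounds, and the source may have more. Where it says the series, first, only, none or still open, it means among the compounds named here.

Compound 1 `CCOCCn1c(N2CCN(C)CC2)nc2ccccc21` is the reference. In a functional assay on ileum for inhibition of histamine H1 receptor (Cavia porcellus) (on this read-out higher numbers stand for weaker inhibition and lower numbers for stronger inhibition), compound 1 gives 10 nM, the lowest of the two numbers in hand; its nearest neighbour is compound 2 `CCOCCn1c(N2CCN(CC)CC2)nc2ccccc21`, which in this assay gives 18 nM, and the step of a 1.8-fold higher number from compound 1 to compound 2 (0.26 log units; within the scatter) separates them. Compound 3 `CCOCCn1c(N2CCN(c3ccccc3)CC2)nc2ccccc21` is known in this assay only as a limit, > 10000 nM, which is the limit of > 10000 nM in this assay, at which 1 of the 3 values shown sits. The steps of an at least 1000-fold higher number from compound 1 to compound 3 (3.00 log units; beyond the scatter) and an at least 550-fold higher number from compound 2 to compound 3 (2.74 log units; beyond the scatter) are the large ones in this set, yet both concern the substituent on the amine nitrogen in the ring, a position that compound 4 `CCCC(C)n1c(N2CCN(C)CC2)nc2ccccc21` leaves exactly as in compound 1.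

The change from compound 1 to compound 4 is 1-methylbutyl in place of 2-ethoxyethyl on an aromatic nitrogen. Within the data shown here, none of the measured steps touches the aromatic nitrogen, so no direct precedent exists for this exchange; the three measured compounds differ only at the amine nitrogen in the ring. The small steps observed elsewhere give no reason to expect a collapse, and the branched chain keeps the same number of heavy atoms as the group it replaces. For compound 4 the expected step is therefore modest, a 2.0-fold higher number from compound 1 to compound 4 (0.30 log units; within the scatter), with no direction firmly supported. Compound 4 is estimated at 20 nM in this assay, within a range from 4 nM to 100 nM.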

Compound 4, half-maximal inhibitory concentration: 1400 nM
For compound 4 the middle estimate is 70-fold (1.85 log units) below the measured one; measured number above the stated range.
By their numbers in this assay, from the lowest: compounds 1 and 2 (each within the scatter of the next); then compound 4. At a limit, above all of these: compound 3.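

Among these compounds, the exchange on the aromatic nitrogen gives, in this assay, a 140-fold higher number from compound 1 to compound 4 (2.15 log units; beyond the scatter), so this position, which the earlier compounds left untouched, bears on the read-out just as the amine nitrogen in the ring does. Keeping the count of heavy atoms is clearly not enough to keep the inhibition, since 2-ethoxyethyl and 1-methylbutyl hold the same count, yet the entering group has no oxygen and no hydrogen-bond acceptor and is branched, so two differences arrive in one step and the data do not separate them. Nothing measured here accounts for the size of this step.

Going by these compounds, what stays open is whether the weaker inhibition goes with the missing ether oxygen or with the branching, a question that an unbranched pentyl chain on the same nitrogen, or a branched chain that keeps the ether oxygen, would address. Also open, on these data alone, is how other groups at the end of this arm, such as a hydroxyl or an amine, would read out on the core of compound 1.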